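Acetyl for Ethyl on the Ring Nitrogen

This account rests on a few compounds, and the source may have more. Where it says the series, first, only, none or still open, it means among the compounds named here.

Measured compounds:
compound 1, `O=C1NCCc2nc(C#Cc3ccccc3)sc21` — 112 nM
compound 2, `CCN1CCc2nc(C#Cc3ccccc3)sc2C1` — > 10000 nM (a limit of the assay, not a number)

Of the compounds shown here, two sharing one core have been tested in an assay on HEK293 cells for positive allosteric modulation of metabotropic glutamate receptor 5 (Homo sapiens), read by FLIPR, with a stated time of 1 h; on this read-out higher numbers stand for an effect only at larger amounts of compound and lower numbers for an effect already at smaller amounts. Compound 1 gives 112 nM, a clear effect at modest amounts of compound. Compound 2 reaches no measurable value in this assay; its result is a limit, and compound 2 stands at the limit of > 10000 nM in this assay, at which 1 of the 2 values shown sits. Going by the values given here, with one value a number and the other only a limit, no measured step between the two can be stated, and the size of the difference between them stays open.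

Compound 3, `CC(=O)N1CCc2nc(C#Cc3ccccc3)sc2C1`, has not yet been measured. It differs from compound 2 in one place: acetyl in place of ethyl on an amine nitrogen in a ring. Among the compounds with values here, no step between measured compounds of this kind exists here, so the expected size of the change rests on the two values alone. The estimated step of an at least 6.6-fold lower number from compound 2 to compound 3 (0.82 log units; beyond the scatter) is expected to move compound 3 toward an effect at smaller amounts than the limit seen for compound 2, though how far remains uncertain. Compound 3 is therefore estimated at 1500 nM, with a range from 300 nM to 10000 nM, and a real chance that this assay again returns only a limit.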

Compound 3, half-maximal effective concentration: > 10000 nM
Compound 3: no number, only a limit (the forecaster's own chance of this, stated with the estimate: 35%); at least 6.6-fold (0.82 log units) between middle value and limit.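

Compound 2 and compound 3 both give only a limit, not a number, in this assay, so no step can be read for acetyl in place of ethyl on an amine nitrogen in a ring: the limit of > 10000 nM in this assay, at which 2 of the 3 values shown sit. The compounds shown leave open how far apart compound 2 and compound 3 really lie, and whether this exchange changes the read-out at all.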